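From 3,5-dimethyl-1,2-oxazol-4-yl to isopropoxy on compound 2

The compounds below may be only part of what the source reports. "The series", "measured", "known", "first", "only" and "open" are said of these compounds alone.

Measured in a functional assay on KARPAS-422 cells (Homo sapiens) for inhibition, with a stated time of 72 h; a lower number here means a stronger inhibitor, a higher number a weaker inhibitor:
Compound 1 `Cc1cc(C)c(CN2CCc3ccc(O[C@@H]4CCOC4)c(Cl)c3C2=O)c(=O)[nH]1`: 512 nM
Compound 2 `Cc1cc(C)c(CN2CCc3ccc(-c4c(C)noc4C)c(Cl)c3C2=O)c(=O)[nH]1`: 121 nM
Compound 3 `Cc1cc(C)c(CN2CCc3c(Cl)cc(-c4c(C)n[nH]c4C)c(Cl)c3C2=O)c(=O)[nH]1`: 959 nM

Compound 2 has the lowest number of the three, making it the strongest inhibitor so far. Compound 4 `Cc1cc(C)c(CN2CCc3ccc(OC(C)C)c(Cl)c3C2=O)c(=O)[nH]1` carries isopropoxy in place of 3,5-dimethyl-1,2-oxazol-4-yl on an aromatic carbon, ortho to a chloro group: isopropoxy in place of 3,5-dimethyl-1,2-oxazol-4-yl on an aromatic carbon. The closest guide is a 4.2-fold lower number from compound 1 to compound 2 (0.63 log units; beyond the scatter), a modest step made by the same group replacing (oxolan-3-yl)oxy. Isopropoxy is also attached through oxygen, so that step should roughly reverse. Compound 3 differs from compound 2 in more than one place and offers no direct guide. In this assay, a modest rise is expected: a 3.7-fold higher number from compound 2 to compound 4 (0.57 log units; beyond the scatter). For compound 4 the estimated value is 450 nM, with an expected range of 180 nM to 1100 nM.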

Compound 4, half-maximal inhibitory concentration: 1160 nM
Compound 4: the middle estimate sits 2.6-fold (0.41 log units) below what was measured; measured number above the stated range.
By their numbers in this assay, from the lowest: compound 2; then compounds 1, 3 and 4 (each within the scatter of the next, the first and the last beyond it).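

In this assay the change to isopropoxy gives a 9.6-fold higher number from compound 2 to compound 4 (0.98 log units; beyond the scatter) and shows that this aromatic carbon, ortho to a chloro group, favours 3,5-dimethyl-1,2-oxazol-4-yl over both groups attached through oxygen. What lies beyond that oxygen also counts, since isopropyl in place of oxolan-3-yl gives a 2.3-fold higher number from compound 1 to compound 4 (0.36 log units; beyond the scatter) and so separates the two ethers. No measurement here explains either step.
From the compounds shown here alone, it remains open whether a simple amine or a carboxylic acid on this carbon would match compound 2. A plain phenyl ring there is equally untested among these compounds.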